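Indolyl for oxadiazolylphenyl: what the limits allow

The source may hold more compounds than are shown below. What is called first, only, known or untested is meant among the compounds shown, and "the series" means these compounds.

Compound 1, `CCOC(=O)CCCCCOc1cccc(CN(C(=O)c2ccccc2)C(C)C)c1`: in an ADME assay on BJ cells (Homo sapiens) for cytotoxicity, read by CellTiter-Glo and resazurin assay, with a stated time of 72 h (a higher number here means that more compound is needed for the effect, a lower number that less compound is needed), compound 1 gives > 26000 nM, which is a limit of the assay rather than a number.
Compound 2, `CCOC(=O)CCCCCOc1cccc(CN(C(=O)c2ccc(-c3ccncc3)cc2)C(C)C)c1`: in this assay compound 2 gives > 26000 nM, again a limit.
Compound 3, `CCOC(=O)CCCCCOc1cccc(CN(C(=O)c2ccc(-c3cccc(-c4nnc(C)o4)c3)cc2)C(C)C)c1`: in this assay compound 3 gives > 26000 nM, again a limit.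

Compound 3 therefore stands exactly where the other two stand, at the limit of > 26000 nM in this assay, at which 3 of the 3 values shown sit. None of the steps among the three can be sized: a step that the two limits leave unreadable from compound 1 to compound 2, a step that the two limits leave unreadable from compound 1 to compound 3, and a step that the two limits leave unreadable from compound 2 to compound 3. All that the numbers show is that none of the three compounds is toxic to these cells within the range the assay covers.

Compound 4, `CCOC(=O)CCCCCOc1cccc(CN(C(=O)c2ccc(-c3ccc4[nH]ccc4c3)cc2)C(C)C)c1`, has not been measured. It differs from compound 3 at the same position where compounds 2 and 3 already differ: 1H-indol-5-yl in place of 3-(5-methyl-1,3,4-oxadiazol-2-yl)phenyl on an aromatic carbon. The two steps that change this position, from compound 1 to compound 3 and from compound 2 to compound 3, both bear on it, and both are unreadable because the limit of > 26000 nM in this assay, at which 3 of the 3 values shown sit, holds for every compound shown.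

Compound 4 is expected to give a value near 30000 nM, somewhere between 12000 nM and 100000 nM, most probably again as a limit. The expected step that the limit leaves unreadable from compound 3 to compound 4 is accordingly none beyond the scatter.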

Compound 4, half-maximal effective concentration: > 26000 nM
Compound 4: only a limit was reported; the forecaster's own chance of this, stated with the estimate: 85%; the middle value is on the limit's open side.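

In this assay compound 4 gives > 26000 nM as a limit of the assay and not a number. Its steps from compound 1, compound 2 and compound 3 cannot be read, because all four compounds sit at the same limit: the limit of > 26000 nM in this assay, at which 4 of the 4 values shown sit. The compounds shown leave open how far apart their true values lie in this assay and whether any change at this position would give a readable value.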